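Triazole to imidazole on the aryl group: compound 3

A few compounds are considered here, and "the series" means these few. Any claim that something is new, unique, unknown or untested is made for them only; others in the source may bear on it.

In a functional assay on NCI-H1975 cells (Homo sapiens) for inhibition, read by sulforhodamine B assay, tested at 10 uM (on this read-out lower numbers stand for less inhibition and higher numbers for more inhibition at the one concentration tested (going by the name of the read-out)), compound 2 `CN(C)c1ccc(C2CC(c3ccc(-n4cncn4)cc3)=NN2C(=O)c2ccc(F)cc2)cc1` gives -1.1%, and compound 1 `CN(C)c1ccc(C2CC(c3ccc(-n4cncn4)cc3)=NN2C(=O)CCCl)cc1` gives -0.7%; on these numbers compound 2 stands level with compound 1, the step of a number 0.4 percentage points lower from compound 1 to compound 2 (within the scatter) lying within the scatter. Compound 3 `CN(C)c1ccc(C2CC(c3ccc(-n4ccnc4)cc3)=NN2C(=O)c2ccc(F)cc2)cc1` differs from compound 2 by 1H-imidazol-1-yl in place of 1H-1,2,4-triazol-1-yl on an aromatic carbon. Among the measured compounds shown here, no measured step alters the 1H-1,2,4-triazol-1-yl group; the only step known, a number 0.4 percentage points lower from compound 1 to compound 2 (within the scatter), concerns the carbonyl substituent and is flat. With both measured numbers near zero, no shift beyond the scatter is expected. Compound 3 is therefore estimated at -1% (range -10% to 9%). The expected step is a number 0.1 percentage points higher from compound 2 to compound 3 (within the scatter).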

Compound 3, a percentage reported as inhibition, at one concentration (the size of the read-out at that concentration, not a potency): -3.5%
Beside the measured number, compound 3's estimate is 2.5 percentage points above it; measured number inside the range.
By their numbers in this assay, from the lowest: compounds 3, 2 and 1 (each within the scatter of the next).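

Among the compounds shown here, this is the first read on the group para to a large group on the six-membered aromatic ring. In this assay, 1H-imidazol-1-yl in place of 1H-1,2,4-triazol-1-yl gives a number 2.4 percentage points lower from compound 2 to compound 3 (within the scatter) and so leaves the number within the scatter, as the step on the carbonyl side did. No evidence bears on this result.

Open, on these data alone, is whether a pyridyl group or a carboxylic acid at this position, or a longer chain on the carbonyl, would move the number beyond the scatter.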